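Removing the fluorine from the mesylate nucleoside

The compounds below may be only part of what the source reports. "The series", "measured", "known", "first", "only" and "open" are said of these compounds alone.

Within the data shown here, compound 2 `CS(=O)(=O)O[C@@H]1[C@@H](O)[C@H](n2cc(F)c(N)nc2=O)O[C@@H]1CO` gives 0.05 ug/mL in a functional assay on L5178Y cells (Mus musculus) for antiproliferative activity (a lower number here means a stronger inhibitor, a higher number a weaker inhibitor), the lowest of the two numbers known; compound 1 `Cc1ccc(S(=O)(=O)O[C@@H]2[C@@H](O)[C@H](n3ccc(N)nc3=O)O[C@@H]2CO)cc1` gives 0.08 ug/mL in this assay, which lies within the scatter of compound 2. Compound 3 `CS(=O)(=O)O[C@@H]1[C@@H](O)[C@H](n2ccc(N)nc2=O)O[C@@H]1CO` has not been measured. Compared with compound 2 it shows (hydrogen in place of fluoro on an aromatic carbon). Among the measured compounds shown here, no step between measured compounds is known for this change, so compound 3 is expected to stay close to compound 2, with a step of a 1.4-fold higher number from compound 2 to compound 3 (0.15 log units; within the scatter) of no more than the scatter in either direction. Compound 3 is estimated at 0.07 ug/mL, in the range 0.03 ug/mL to 0.18 ug/mL.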

Compound 3, concentration for 50% inhibition: 0.07 ug/mL
Compound 3: middle estimate and measured number agree at the digits printed, and the stated range covers the measured number.
By their numbers in this assay, from the lowest: compounds 2, 3 and 1 (each within the scatter of the next).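

In this assay, hydrogen in place of fluoro on the aromatic carbon gives a 1.4-fold higher number from compound 2 to compound 3 (0.15 log units; within the scatter), so at this position the fluoro group can go without a step beyond the scatter. Methyl in place of 4-methylphenyl on the sulfonyl sulfur gives a 1.1-fold lower number from compound 1 to compound 3 (0.06 log units; within the scatter), which puts the two sulfonyl substituents within the scatter on the same unfluorinated core. Nothing available accounts for either step.

Open, on these data alone, is whether chloro, methyl or an amine on that aromatic carbon would keep the number within the scatter. Also open, as far as these compounds go, is what a longer chain on the sulfonyl sulfur would do.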